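Adding a hydroxy group to compound 3

The source may report more compounds than this note shows. Statements on the series, on what has been measured and on what is new or still open speak of the compounds shown alone.

For the measured compounds named here, in a functional assay on KB cells (Homo sapiens) for antiproliferative activity, read by colorimetric assay and MTT assay (a higher number here means a weaker inhibitor, a lower number a stronger inhibitor), compound 3 (`Nc1ccc(S(=O)(=O)Nc2cccc3cc[nH]c23)cc1`) reads 36 ug/mL, the highest number of the three measured so far. Compound 2 (`O=S(=O)(Nc1cccc2cc[nH]c12)c1ccc(Cl)cc1`) gives 6 ug/mL, and the step between them is a 6.0-fold higher number from compound 2 to compound 3 (0.78 log units; beyond the scatter). Compound 4 (`Nc1ccc(S(=O)(=O)Nc2cccc3cc(O)[nH]c23)cc1`) carries hydroxy in place of hydrogen on an aromatic carbon. Going by the values given here, no measured step shows this change alone. The closest evidence is compound 1 (`COc1ccc(S(=O)(=O)Nc2cccc3cc(O)[nH]c23)cc1`), which already holds that hydroxy but differs from compound 4 in a second place. Compound 1 gives 0.1 ug/mL. A large fall is therefore expected in this assay, with much uncertainty: the expected change is a 24-fold lower number from compound 3 to compound 4 (1.38 log units; beyond the scatter). Compound 4 is estimated at 1.5 ug/mL, with an expected range from 0.15 ug/mL to 15 ug/mL.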

Compound 4, half-maximal inhibitory concentration: 0.86 ug/mL
Estimate against measurement, compound 4: 1.7-fold (0.24 log units) above; measured number inside the range.
By their numbers in this assay, from the lowest: compound 1; then compound 4; then compound 2; then compound 3.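

In this assay, hydroxy on the aromatic carbon next to the ring nitrogen now has a step of its own, a 42-fold lower number from compound 3 to compound 4 (1.62 log units; beyond the scatter), with nothing else in the molecule changed. With that hydroxy kept, amino in place of methoxy still gives an 8.6-fold higher number from compound 1 to compound 4 (0.93 log units; beyond the scatter), so the hydroxy alone does not set the number. Nothing measured here explains either step.

Still open, on these data alone, is whether an amine or a methoxy group on that same carbon would give a similar fall, and whether hydroxy there would also lower the number for compound 2.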